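The source may hold more compounds than are shown below. What is called first, only, known or untested is meant among the compounds shown, and "the series" means these compounds.

Measured so far:
compound 1, `Cc1ccccc1-c1c(C)nn(-c2nc(-c3ccc(Cl)c(Cl)c3)c(SC(C)C)s2)c1C(=O)O` — 5500 nM
compound 2, `Cc1nn(-c2nc(-c3ccc(Cl)c(Cl)c3)c(SC(C)C)s2)c(C(=O)O)c1-c1cnn(C)c1` — 6800 nM
compound 3, `Cc1nn(-c2nc(-c3ccc(Cl)c(Cl)c3)c(SC(C)C)s2)c(C(=O)O)c1-c1cccc(C(F)(F)F)c1` — 22000 nM

These three compounds share one core and differ only in the group on an aromatic carbon of the five-membered ring. In a functional assay on BJAB cells (Homo sapiens) for antiproliferative activity, with a stated time of 4 days (on this read-out lower numbers stand for an effect already at smaller amounts and higher numbers for an effect only at larger amounts of compound), compound 3 gives the highest of the three numbers, with compound 2 nearest at a 3.2-fold higher number from compound 2 to compound 3 (0.51 log units; beyond the scatter) and compound 1 furthest at a 4.0-fold higher number from compound 1 to compound 3 (0.60 log units; beyond the scatter). Compound 4, `Cc1nn(-c2nc(-c3ccc(Cl)c(Cl)c3)c(SC(C)C)s2)c(C(=O)O)c1-c1ccccc1C(F)(F)F`, has not been measured in this assay. It differs from compound 3 by 2-(trifluoromethyl)phenyl in place of 3-(trifluoromethyl)phenyl on an aromatic carbon.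

Among the compounds with values here, no measured step moves the same substituent from one place on the phenyl ring to another, so the steps bear on this change only indirectly. Compound 1 carries a 2-methylphenyl and stands lower than compound 3 by a 4.0-fold higher number from compound 1 to compound 3 (0.60 log units; beyond the scatter); compound 2 stands lower by a 3.2-fold higher number from compound 2 to compound 3 (0.51 log units; beyond the scatter). Both say that compound 3 is the weakest point of the series, so a return toward the range of compounds 1 and 2 is expected rather than a further rise. Compound 4 is therefore estimated to lie below compound 3, with a step of a 2.4-fold lower number from compound 3 to compound 4 (0.39 log units; beyond the scatter), though the absence of a direct comparison keeps the range wide. The expected value for compound 4 in this assay is 9000 nM, between 3000 nM and 27000 nM.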

Compound 4, half-maximal effective concentration: 5200 nM
The estimate for compound 4 lay 1.7-fold (0.24 log units) above the measured number; the measured number falls inside the stated range.
By their numbers in this assay, from the lowest: compounds 4, 1 and 2 (each within the scatter of the next); then compound 3.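

In this assay, moving the trifluoromethyl group on the phenyl ring gives a 4.2-fold lower number from compound 3 to compound 4 (0.63 log units; beyond the scatter). Within the data shown here, this shows that the same atoms, joined differently at this position, are enough to separate compound 3 from the others, which the earlier compounds, differing in the whole group, could not show. The remaining steps, a 1.1-fold lower number from compound 1 to compound 4 (0.02 log units; within the scatter) for trifluoromethyl in place of methyl and a 1.3-fold lower number from compound 2 to compound 4 (0.12 log units; within the scatter) for 2-(trifluoromethyl)phenyl in place of 1-methyl-1H-pyrazol-4-yl, lie within the scatter, and no measurement here explains the effect of moving the group.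

The compounds shown leave open whether a 3-methylphenyl would stand with compound 3 or with compound 1. They also leave open whether a 2-methoxyphenyl or a 2-aminophenyl would stay in the range of compound 4.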